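Moving the chlorine on the chlorophenyl group

The compounds below may be only part of what the source reports. "The series", "measured", "known", "first", "only" and "open" are said of these compounds alone.

Going by the values given here, compound 2 `Cc1nc(-c2ccccc2Cl)sc1COc1ccc2c(c1)OCC2CC(=O)O` stands lowest of the two numbers measured so far in a functional assay on CHO cells for agonist activity at Free fatty acid receptor 1 (Homo sapiens), read by FLIPR and calcium flux, tested at 100 nM (a lower number here means a weaker effect, a higher number a stronger effect of the compound at the concentration tested), giving 12.4%. Its nearest neighbour is compound 1 `Cc1nc(-c2cc3ccccc3o2)sc1COc1ccc2c(c1)OCC2CC(=O)O`, which in this assay gives 14.8%; the step of a number 2.4 percentage points lower from compound 1 to compound 2 (within the scatter) lies within the scatter, so the two cannot be ordered. Compound 3 `Cc1nc(-c2cccc(Cl)c2)sc1COc1ccc2c(c1)OCC2CC(=O)O` differs from compound 2 in one place: 3-chlorophenyl in place of 2-chlorophenyl on an aromatic carbon. Among the compounds with values here, no measured step bears directly on this change. Within the data shown here, the only step recorded, a number 2.4 percentage points lower from compound 1 to compound 2 (within the scatter), exchanges a different group on an aromatic carbon and stayed within the scatter, so it offers no direction to expect here. For compound 3 a shift in this assay of no size beyond the scatter is therefore expected, as a number 0.6 percentage points higher from compound 2 to compound 3 (within the scatter). Compound 3 is estimated to give 13% in this assay, within a range from 4% to 26%.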

Compound 3, a percentage reported as activity, at one concentration (the size of the read-out at that concentration, not a potency): 43%
Beside the measured number, compound 3's estimate is 30 percentage points below it; the whole stated range lies below it.
By their numbers in this assay, from the lowest: compounds 2 and 1 (each within the scatter of the next); then compound 3.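

In this assay, the aromatic carbon next to the ring nitrogen and next to the ring sulfur carries a group whose chlorine placement matters: with the same atoms joined differently, the change to 3-chlorophenyl gives a number 30.6 percentage points higher from compound 2 to compound 3 (beyond the scatter) and separates two compounds by this one shift alone. The 3-chlorophenyl group also stands clear of the 1-benzofuran-2-yl group, with a number 28.2 percentage points higher from compound 1 to compound 3 (beyond the scatter) at this place, something the earlier step between 1-benzofuran-2-yl and 2-chlorophenyl could not show. Nothing at hand accounts for the size of this effect.

Open, on these data alone, is whether the rise belongs to chlorine itself or to any group at that place on the phenyl ring, such as fluorine, methoxy or trifluoromethyl. A read-out at one concentration also shows the stronger effect of compound 3 over compound 2 at that concentration only.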